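Replacing the Chlorinated Ring on the Shared Core

This account rests on a few compounds, and the source may have more. Where it says the series, first, only, none or still open, it means among the compounds named here.

Compound 1, `N[C@]1(C(=O)O)[C@H]2[C@@H](C[C@H]1OCc1cccc(Cl)c1)[C@]2(F)C(=O)O`: 3.28 nM
Compound 2, `N[C@]1(C(=O)O)[C@H]2[C@@H](C[C@H]1OCc1cccc(-c3ccccc3)c1)[C@]2(F)C(=O)O`: 9.34 nM
Compound 3, `N[C@]1(C(=O)O)[C@H]2[C@@H](C[C@H]1OCc1cccc(Oc3ccccc3)c1)[C@]2(F)C(=O)O`: 7.15 nM

Three compounds share one core and differ only in the aromatic ring that hangs from it. In an assay on CHO cells for binding affinity to metabotropic glutamate receptor 2 (Rattus norvegicus) (a higher number here means a weaker inhibitor, a lower number a stronger inhibitor), compound 1 gives 3.28 nM, the lowest of the three numbers, with compound 3 nearest and compound 2 furthest from it. Both changes away from chloro moved the number upward by a modest amount: a 2.8-fold higher number from compound 1 to compound 2 (0.45 log units; beyond the scatter) and a 2.2-fold higher number from compound 1 to compound 3 (0.34 log units; beyond the scatter). Compound 2 and compound 3 sit within the scatter of each other, so nothing separates them.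

Compound 4, `N[C@]1(C(=O)O)[C@H]2[C@@H](C[C@H]1OCc1cc(F)ccc1F)[C@]2(F)C(=O)O`, has not yet been measured. It differs from compound 1 as follows: 2,5-difluorophenyl in place of 3-chlorophenyl on a saturated chain carbon bound to an oxygen on a saturated carbon. Within the data shown here, no measured step exchanges one halogen pattern for another on this ring; the only steps that bear on the change are the two from compound 1, both modest and both upward, and both introduce a second ring rather than new halogens. On that basis a small upward step, or none beyond the scatter, is expected. For compound 4 the estimate in this assay is 4.5 nM, within a range of 1.6 nM to 13 nM, which is expected to mean a step of a 1.4-fold higher number from compound 1 to compound 4 (0.14 log units; within the scatter).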

Compound 4, inhibition constant: 14.4 nM
Compound 4: middle estimate off by 3.2-fold (0.51 log units), on the low side, and the stated range ends below it.
By their numbers in this assay, from the lowest: compound 1; then compounds 3, 2 and 4 (each within the scatter of the next).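

The change at this position need not add a second ring to raise the number: swapping 3-chlorophenyl for 2,5-difluorophenyl on the saturated chain carbon keeps a single six-membered aromatic ring of carbon only and no net charge, yet this assay records a 4.4-fold higher number from compound 1 to compound 4 (0.64 log units; beyond the scatter) in this case. Halogens on this ring therefore matter to the result, and which halogens are present, or where they sit, cannot be treated as interchangeable, with compound 1 now lowest among all four compounds and every change away from its 3-chlorophenyl group raising the number. Nothing available on the compounds explains why this swap raises the number.

The compounds shown leave open whether the rise follows the loss of the chlorine or the arrival of the two fluorines, as both happen in the one step. A plain phenyl ring, or a ring carrying a single fluorine, a methyl or a methoxy group on this same chain carbon, would begin to pull those two parts of the change apart.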